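This account rests on a few compounds, and the source may have more. Where it says the series, first, only, none or still open, it means among the compounds named here.

Three compounds of this series carry a measured cytotoxicity so far. Compound 1 `Cc1cncc(C(=O)n2c(-c3cn(-c4ccccc4)nc3-c3ccc(F)cc3)nc3ccccc32)c1` gives 119000 nM in an ADME assay on HEK-293T cells (Homo sapiens) for cytotoxicity, read by MTT assay, with a stated time of 24 h; on this read-out lower numbers stand for higher toxicity in this test and higher numbers for lower toxicity in this test. Compound 2 `Cc1ccc(-c2nn(-c3ccccc3)cc2-c2nc3ccccc3n2C(=O)c2cccc(C)c2)cc1` gives 195000 nM in this assay, and compound 3 `Cc1ccc(-c2nn(-c3ccccc3)cc2-c2nc3ccccc3n2C(=O)c2cncc(C)c2)cc1` gives 155000 nM in this assay. Compounds 3 and 1 share the same core and differ by fluoro in place of methyl on an aromatic carbon; this change made a step of a 1.3-fold lower number from compound 3 to compound 1 (0.11 log units; within the scatter). Compounds 3 and 2 differ in the core itself, by 3-methylphenyl in place of 5-methylpyridin-3-yl on a carbonyl carbon, and that difference came with a step of a 1.3-fold lower number from compound 2 to compound 3 (0.10 log units; within the scatter). All three numbers sit within the scatter of one another, so no order among them is claimed.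

Compound 4 `Cc1cccc(C(=O)n2c(-c3cn(-c4ccccc4)nc3-c3ccc(F)cc3)nc3ccccc32)c1` has not yet been tested in this assay. It differs from compound 2 by fluoro in place of methyl on an aromatic carbon, which is the same change as that from compound 3 to compound 1, now made on the core of compound 2. Among the compounds with values here, the step from compound 2 to compound 4 in this assay is expected to be a 1.3-fold lower number from compound 2 to compound 4 (0.11 log units; within the scatter), of similar size and direction as the only measured example of this change. This expectation rests on the step of a 1.3-fold lower number from compound 3 to compound 1 (0.11 log units; within the scatter), which stayed within the scatter. Compound 4 is therefore estimated at 150000 nM, expected to fall between 85000 nM and 270000 nM.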

Compound 4, half-maximal cytotoxic concentration: 148000 nM
The estimate for compound 4 lay 1.0-fold (0.01 log units) above the measured number; the range from low to high includes it.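

In this assay, 4-methylphenyl to 4-fluorophenyl gives a 1.3-fold lower number from compound 2 to compound 4 (0.12 log units; within the scatter), and this change carries from one core to the other without a detectable difference: the same change on two cores in this assay, a 1.3-fold lower number (0.11 log units; within the scatter) from compound 3 to compound 1 and a 1.3-fold lower number (0.12 log units; within the scatter) from compound 2 to compound 4, 1.0-fold (0.00 log units) apart, within the scatter of two such steps
The exchange of 5-methylpyridin-3-yl and 3-methylphenyl on the carbonyl carbon, read here as a 1.2-fold higher number from compound 1 to compound 4 (0.09 log units; within the scatter), likewise agrees across the two cores: the same change on two cores in this assay, a 1.3-fold lower number (0.10 log units; within the scatter) from compound 2 to compound 3 and a 1.2-fold lower number (0.09 log units; within the scatter) from compound 4 to compound 1, 1.0-fold (0.00 log units) apart, within the scatter of two such steps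
Within the data shown here, the four compounds therefore fit simple carry-over of both changes, but every step lies within the scatter, so this agreement is between steps that cannot be told from no step at all, and it shows neither a real effect of either change nor transfer of a larger effect to further cores.

On these data alone, whether an amine or a carboxylic acid in place of the fluoro, or a longer chain in place of the methyl on the carbonyl-bearing ring, would give a step beyond the scatter remains open. The compounds shown also leave open whether the same agreement would hold in other cell lines or at other exposure times.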